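A few compounds are considered here, and "the series" means these few. Any claim that something is new, unique, unknown or untested is made for them only; others in the source may bear on it.

In a functional assay on KYSE-70 cells for antiproliferative activity against KYSE-70 cell line (Homo sapiens), read by MTT assay, with a stated time of 72 h (a lower number here means a stronger inhibitor, a higher number a weaker inhibitor), compound 1 `O=C(Nc1ccc(Cl)cc1)c1ccnc2cc(Br)ccc12` gives only a limit, > 20000 nM. Compound 2 `COc1cccc(NC(=O)c2cc(=O)[nH]c3cc(Br)ccc23)c1` also gives only a limit, > 20000 nM. Compound 3 `COc1ccc(-c2ccc3c(C(=O)Nc4cccc(F)c4)cc(=O)[nH]c3c2)cc1` likewise returns a limit and no number, > 20000 nM. The three compounds therefore share one reading: the limit of > 20000 nM in this assay, at which 3 of the 3 values shown sit. Compound 3 thus stands with the other two, and it offers no measured potency from which to count a change.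

Compound 4 `Nc1ccc(-c2ccc3c(C(=O)Nc4cccc(F)c4)cc(=O)[nH]c3c2)cc1` differs from compound 3 in a single group, with 4-methoxyphenyl changed to 4-aminophenyl: amino in place of methoxy on an aromatic carbon. The amino group takes the place of methoxy on an aromatic carbon, para to a large group. Going by the values given here, no measured pair of compounds shows what this swap does in this assay, so only a modest shift towards stronger inhibition is expected, and the result may well remain a limit. The estimated change is an at least 1.3-fold lower number from compound 3 to compound 4 (0.12 log units; that floor lies within the scatter). For compound 4 the estimated half-maximal inhibitory concentration is 15000 nM, with an expected range from 4000 nM to 40000 nM.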

Compound 4, half-maximal inhibitory concentration: > 20000 nM
Compound 4: no number, only a limit; the forecaster's own chance of this, stated with the estimate: 55%; middle value at least 1.3-fold (0.12 log units) from the limit.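

In this assay compound 4 gives > 20000 nM as a limit and not a number. Compound 3 also stands at a limit, so no step can be read between compound 3 and compound 4: the limit of > 20000 nM in this assay, at which 4 of the 4 values shown sit. The compounds shown leave open which structure, if any, would give a measured potency in this assay.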